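The source may hold more compounds than are shown below. What is called first, only, known or untested is meant among the compounds shown, and "the series" means these compounds.

Measured compounds in a functional assay on KBVIN cells (Homo sapiens) for cytotoxicity, read by MTT assay, with a stated time of 72 h; a lower number here means that less compound is needed, a higher number that more compound is needed for the effect:
compound 1 `CCOc1c(-c2occ(C)c2C(=O)OC)ccc2c(CC)cccc12` gives 1.7 ug/mL;
compound 2 `CCOc1c(-c2occ(C)c2CO)ccc2c(CC)cccc12` gives 6.4 ug/mL;
compound 3 `CCc1cccc2c(OC)c(-c3occ(C)c3COC)ccc12` gives 8.8 ug/mL.

Compound 3 stands at the highest of the three numbers in this assay. Its nearest neighbour is compound 2, whose number is lower only within the scatter, so the two cannot be told apart; compound 1 lies furthest away, with a number lower than that of compound 3 by a margin beyond the scatter.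

Compound 4 `CCOc1c(-c2occ(C)c2COC)ccc2c(CC)cccc12` differs from compound 3 by methyl in place of hydrogen on a saturated chain carbon bound to an oxygen on an aromatic ring. Going by the values given here, the one measured step, a 3.8-fold higher number from compound 1 to compound 2 (0.58 log units; beyond the scatter), concerns a different site and a different kind of group, so it does not speak to this change. Among the compounds with values here, no pair among the measured compounds differs only at the oxygen on the aromatic ring. With nothing to anchor the step, the change from compound 3 to compound 4 is expected to stay within the scatter, a 1.3-fold lower number from compound 3 to compound 4 (0.10 log units; within the scatter). Compound 4 is therefore estimated at 7 ug/mL, with a range from 3.5 ug/mL to 14 ug/mL.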

Compound 4, concentration for half-maximal effect: 5.9 ug/mL
Compound 4: the middle estimate sits 1.2-fold (0.07 log units) above what was measured, within the range that was stated.
By their numbers in this assay, from the lowest: compound 1; then compounds 4, 2 and 3 (each within the scatter of the next).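

Methoxy to ethoxy, methyl in place of hydrogen on a saturated chain carbon bound to an oxygen on an aromatic ring, can now be read as a single change, and in this assay it stays within the scatter (a 1.5-fold lower number from compound 3 to compound 4 (0.17 log units; within the scatter)). The new compound also links the side group on the other ring: methyl in place of hydrogen on the hydroxymethyl oxygen leaves the two compounds indistinguishable (a 1.1-fold lower number from compound 2 to compound 4 (0.04 log units; within the scatter)), while methoxymethyl in place of methoxycarbonyl gives a step beyond the scatter (a 3.5-fold higher number from compound 1 to compound 4 (0.54 log units; beyond the scatter)), of a similar size to the step to hydroxymethyl (a 3.8-fold higher number from compound 1 to compound 2 (0.58 log units; beyond the scatter)). Nothing measured here explains these steps.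

Going by these compounds, whether a longer chain than ethoxy on that oxygen would also stay within the scatter remains open. So does how an amide or a carboxylic acid in place of methoxycarbonyl would compare.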